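The source may hold more compounds than are shown below. What is called first, only, known or untested is meant among the compounds shown, and "the series" means these compounds.

Measured compounds:
compound 1 `C=CCN1CCC(c2noc(COc3ccc(/C=C/C(=O)NO)cc3)n2)CC1` — 66%
compound 2 `O=C(/C=C/c1ccc(OCc2nc(C3CCN(Cc4ccccc4)CC3)no2)cc1)NO` — 71%
compound 3 `Cc1ccc(CN2CCC(c3noc(COc4ccc(/C=C/C(=O)NO)cc4)n3)CC2)cc1` — 76%

In an assay on isolated protein for inhibition of protein deacetylase HDAC6 (Homo sapiens), read by fluorescence, with a stated time of 1 h, tested at 100 nM (a lower number here means less inhibition, a higher number more inhibition at the concentration tested (going by the name of the read-out)), compound 1 gives 66%. Compound 2 gives 71%. Compound 3 gives 76%, the highest number of the three, but its steps from the others, a number 10 percentage points higher from compound 1 to compound 3 (within the scatter) and a number 5 percentage points higher from compound 2 to compound 3 (within the scatter), are both within the scatter, so the three compounds stand level on these numbers.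

Compound 4 `O=C(/C=C/c1ccc(OCc2nc(C3CCN(Cc4ccccc4F)CC3)no2)cc1)NO` differs from compound 3 by 2-fluorophenyl in place of 4-methylphenyl on a saturated chain carbon bound to an amine nitrogen in a ring. Within the data shown here, the steps that bear on this change are those on the same saturated chain carbon bound to an amine nitrogen in a ring: a number 5 percentage points higher from compound 1 to compound 2 (within the scatter), a number 10 percentage points higher from compound 1 to compound 3 (within the scatter), and the aromatic-carbon substitution a number 5 percentage points higher from compound 2 to compound 3 (within the scatter). None of them left the scatter; exchanging one group for another at this place has so far not moved the read-out beyond noise. A step within the scatter is therefore expected in this assay, with no direction claimed. Compound 4 is expected to give 72%, between 60% and 84%. The expected step of a number 4 percentage points lower from compound 3 to compound 4 (within the scatter) is thus within the scatter.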

Compound 4, a percentage reported as inhibition, at one concentration (the size of the read-out at that concentration, not a potency): 68%
Estimate against measurement, compound 4: 4 percentage points above; measured number inside the range.
By their numbers in this assay, from the lowest: compounds 1, 4, 2 and 3 (each within the scatter of the next).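

In this assay fluorine is new at this place among the compounds shown: 2-fluorophenyl in place of 4-methylphenyl gives a number 8 percentage points lower from compound 3 to compound 4 (within the scatter) and adding the fluoro group to the unsubstituted aromatic ring gives a number 3 percentage points lower from compound 2 to compound 4 (within the scatter) in this series. Against vinyl on the same saturated chain carbon bound to an amine nitrogen in a ring, 2-fluorophenyl gives a number 2 percentage points higher from compound 1 to compound 4 (within the scatter) so all four groups at this place stand level, whether the aromatic ring carries fluoro, methyl or neither. Nothing available bears on the reason for this flat picture.

From the compounds shown here alone, whether a carboxylic acid or an amine on the benzyl group, or a longer chain in its place, would move the read-out beyond the scatter stays open. Going by these compounds, with a single tested concentration, potency also stays open.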